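From 3-bromophenyl to 4-chlorophenyl on a shared core

The source may report more compounds than this note shows. Statements on the series, on what has been measured and on what is new or still open speak of the compounds shown alone.

In a functional assay on A549 cells (Homo sapiens) for antiproliferative activity, read by MTT assay, with a stated time of 72 h (a higher number here means a weaker inhibitor, a lower number a stronger inhibitor), compound 1 `COc1cc2ncnc(Nc3cccc(Br)c3)c2cc1OCCCCC(=O)Nc1ccc(S(N)(=O)=O)cc1` gives 14900 nM. Within the data shown here, the only comparison is compound 2 `COc1cc2ncnc(Nc3cccc(Cl)c3)c2cc1OCCCCC(=O)Nc1ccc(S(N)(=O)=O)cc1` at 11200 nM, and these two values lie within the scatter of each other. Compound 3 `COc1cc2ncnc(Nc3ccc(Cl)cc3)c2cc1OCCCCC(=O)Nc1ccc(S(N)(=O)=O)cc1` has not been measured, and it differs from compound 1 as follows: 4-chlorophenyl in place of 3-bromophenyl on a nitrogen on an aromatic ring. Among the measured compounds shown here, the one measured step that bears on this is a 1.3-fold lower number from compound 1 to compound 2 (0.12 log units; within the scatter), with chloro in place of bromo. For the measured compounds named here, no measured compound carries the 4-chlorophenyl group, so the data offer no sign of a larger effect, and no step beyond the scatter is expected in this assay. The expected step is a 1.2-fold lower number from compound 1 to compound 3 (0.09 log units; within the scatter). Compound 3 is estimated at 12000 nM, with an expected range of 5000 nM to 30000 nM.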

Compound 3, half-maximal inhibitory concentration: > 40000 nM
Compound 3: no number, only a limit; the forecaster's own chance of this, stated with the estimate: 8%; at least 3.3-fold (0.52 log units) between middle value and limit.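

In this assay, compound 3 gives > 40000 nM, which is a limit of the assay and not a number. Even so, the group on this nitrogen clearly matters: there is an at least 3.5-fold higher number from compound 2 to compound 3 (0.55 log units; beyond the scatter) when 4-chlorophenyl replaces 3-chlorophenyl, and an at least 2.6-fold higher number from compound 1 to compound 3 (0.42 log units; beyond the scatter) when it replaces 3-bromophenyl. The earlier pair showed only that chloro for bromo stays within the scatter, so the ring's substitution pattern can count for more than the choice of halogen in these compounds.

From the compounds shown here alone, how much weaker compound 3 really is stays open: the limit of > 40000 nM in this assay, at which 1 of the 3 values shown sits A 4-bromophenyl or an unsubstituted phenyl group on the same nitrogen would show whether other groups behave the same way.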